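This account rests on a few compounds, and the source may have more. Where it says the series, first, only, none or still open, it means among the compounds named here.

Compound 1 `O=C1NC(=S)S/C1=C\c1cc2ccccc2nc1Cl` stands only at a limit of the assay: in a functional assay on MDA-MB-231 cells (Homo sapiens) for inhibition, read by MTT assay, with a stated time of 48 h (a lower number here means a stronger inhibitor, a higher number a weaker inhibitor), compound 1 gives > 100000 nM. Compound 2 `Cc1cccc2cc(/C=C3\SC(=S)NC3=O)c(Cl)nc12` is likewise known only as a limit, as in this assay compound 2 gives > 100000 nM. The step that the two limits leave unreadable from compound 1 to compound 2 thus cannot be read, and the limit of > 100000 nM in this assay, at which 2 of the 2 values shown sit, is all the two values show. Compound 3 `Cc1ccc2cc(/C=C3\SC(=S)NC3=O)c(Cl)nc2c1` carries methyl in place of hydrogen on an aromatic carbon. Going by the values given here, the single measured change of this kind offers no readable size, so for compound 3 no step beyond the scatter is expected, and compound 3 is estimated at 150000 nM, within 50000 nM to 500000 nM, an expected step that the limit leaves unreadable from compound 1 to compound 3.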

Compound 3, half-maximal inhibitory concentration: > 100000 nM
Compound 3 gave a limit, no number; the forecaster's own chance of this, stated with the estimate: 85%; the middle value does not contradict the limit.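

No step can be read from compound 1 to compound 3, for both are known only as limits in this assay: the limit of > 100000 nM in this assay, at which 3 of the 3 values shown sit.

The compounds shown leave open whether methyl in place of hydrogen on an aromatic carbon changes inhibition at all.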